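The source may report more compounds than this note shows. Statements on the series, on what has been measured and on what is new or still open speak of the compounds shown alone.

Measured so far: compound 1 `Nc1nn2c(O)cc(-c3ccccc3)nc2c1[N+](=O)[O-]` with > 100 ug/mL; compound 2 `NNCc1cc(O)n2nc(N)c([N+](=O)[O-])c2n1` with 42.6 ug/mL.

In an ADME assay (Homo sapiens) for cytotoxicity (a higher number here means that more compound is tolerated, a lower number that less compound is tolerated), compound 1 reports only a limit, > 100 ug/mL, so it stands at the limit of > 100 ug/mL in this assay, at which 1 of the 2 values shown sits, rather than at a number. Compound 2 gives 42.6 ug/mL in this assay. Among the compounds with values here, the one measured step, an at least 2.3-fold lower number from compound 1 to compound 2 (0.37 log units; beyond the scatter), swaps phenyl for a short chain. Compound 3 `Nc1nn2c(O)cc(CNCCO)nc2c1[N+](=O)[O-]` differs from compound 1 by ((2-hydroxyethyl)amino)methyl in place of phenyl on an aromatic carbon, again phenyl giving way to a short chain. Because compound 1 to compound 2 shows an at least 2.3-fold lower number from compound 1 to compound 2 (0.37 log units; beyond the scatter), a drop of comparable size is expected for compound 3: an at least 2.0-fold lower number from compound 1 to compound 3 (0.30 log units; that floor lies within the scatter). Compound 3 is estimated at 50 ug/mL, within 25 ug/mL to 100 ug/mL.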

Compound 3, half-maximal cytotoxic concentration: > 50 ug/mL
Compound 3: only a limit was reported; the forecaster's own chance of this, stated with the estimate: 35%; the middle value lies on the limit itself.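

In this assay compound 3 reports only a limit, > 50 ug/mL. On the amine nitrogen of the short chain, 2-hydroxyethyl in place of amino gives an at least 1.1-fold higher number from compound 2 to compound 3 (0.06 log units; that floor lies within the scatter), a floor within the scatter, so no order between these two chains can be stated. The step from compound 1 to compound 3 cannot be read; both values are limits.

Still open, going by these compounds, is the actual number for compound 3 and whether replacing phenyl costs anything with this chain. Also open, on these data alone, is how a longer chain or a carboxylic acid on the same amine nitrogen would read in this assay.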